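Removing One Chloro from the Dichlorophenyl Ring

The source may report more compounds than this note shows. Statements on the series, on what has been measured and on what is new or still open speak of the compounds shown alone.

Three compounds have been measured in a functional assay on U-87MG ATCC cells for antiproliferative activity against U-87 MG (Homo sapiens), read by MTT assay, with a stated time of 48 h, tested at 5 uM; a higher number here means a weaker effect of the compound at the concentration tested, a lower number a stronger effect:

Compound 1 `COc1ccc(-c2nc(C)c(C(=O)CSc3nc(-c4cccc(OC)c4)c(C#N)c(=O)[nH]3)s2)cc1` gives 71.3%.
Compound 2 `COc1ccc(-c2nc(C)c(C(=O)CSc3nc(-c4ccc(OC)c(OC)c4)c(C#N)c(=O)[nH]3)s2)cc1` gives 81.2%.
Compound 3 `COc1ccc(-c2nc(C)c(C(=O)CSc3nc(-c4ccc(Cl)c(Cl)c4)c(C#N)c(=O)[nH]3)s2)cc1` gives 101%.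

Compound 3 stands highest of the three, beyond the scatter from both others, so its effect at the tested concentration is the weakest of the set. The steps leading to it are a number 29.7 percentage points higher from compound 1 to compound 3 (beyond the scatter) and a number 19.8 percentage points higher from compound 2 to compound 3 (beyond the scatter), whereas a number 9.9 percentage points higher from compound 1 to compound 2 (within the scatter) stays within the scatter.

Compound 4 `COc1ccc(-c2nc(C)c(C(=O)CSc3nc(-c4cccc(Cl)c4)c(C#N)c(=O)[nH]3)s2)cc1` differs from compound 3 by hydrogen in place of chloro on an aromatic carbon. Among the measured compounds shown here, no measured step removes a chloro at this position; the nearest comparison is the addition of a methoxy at the same position, a number 9.9 percentage points higher from compound 1 to compound 2 (within the scatter), which changed little. Compound 4 is therefore expected to sit between compound 3 and the methoxy compounds, with a small downward step estimated as a number 11 percentage points lower from compound 3 to compound 4 (beyond the scatter). The estimate for compound 4 is 90%, in a range from 72% to 106%.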

Compound 4, a percentage reported as activity, at one concentration (the size of the read-out at that concentration, not a potency): 95.7%
Compound 4: middle estimate off by 5.7 percentage points, on the low side; the measured number falls inside the stated range.
By their numbers in this assay, from the lowest: compounds 1 and 2 (each within the scatter of the next); then compounds 4 and 3 (each within the scatter of the next).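

In this assay, the chloro at this place on the ring proves dispensable: with a number 5.3 percentage points lower from compound 3 to compound 4 (within the scatter), compound 3 and compound 4 cannot be told apart. The single chloro on the ring is enough to keep the number apart from those of the methoxy compounds, with a number 24.4 percentage points higher from compound 1 to compound 4 (beyond the scatter) for chloro in place of methoxy and a number 14.5 percentage points higher from compound 2 to compound 4 (beyond the scatter) against the 3,4-dimethoxyphenyl ring, so the earlier gap does not depend on having both chloro groups. Nothing measured here explains this difference between chloro and methoxy.

The compounds shown leave open what happens when the remaining chloro also gives way to hydrogen. They also leave open whether an amine or a carboxylic acid on this ring would bring the number below that of the methoxy compounds.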